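Vinyl Ester in Place of 3-Methylphenyl Ester: Cytotoxicity Outlook

The source may report more compounds than this note shows. Statements on the series, on what has been measured and on what is new or still open speak of the compounds shown alone.

Compound 1 `Cc1cccc(C(=O)OC2CCC(CN3CCN(c4cc(=O)c5cc(C(F)(F)F)cc([N+](=O)[O-])c5s4)CC3)CC2)c1` gives in an ADME assay on Vero cells (Chlorocebus sabaeus) for cytotoxicity, read by MTT assay, with a stated time of 48 h (a lower number here means a stronger inhibitor, a higher number a weaker inhibitor), only a limit, > 64 ug/mL, and no number. Compound 2 `CC(C)C(=O)OC1CCC(CN2CCN(c3cc(=O)c4cc(C(F)(F)F)cc([N+](=O)[O-])c4s3)CC2)CC1` likewise reaches only the limit > 64 ug/mL in this assay. Compound 3 `O=C(OC1CCC(CN2CCN(c3cc(=O)c4cc(C(F)(F)F)cc([N+](=O)[O-])c4s3)CC2)CC1)c1cccc(C(F)(F)F)c1` too gives a limit of > 64 ug/mL in this assay. The steps between these three are therefore unreadable: a step that the two limits leave unreadable from compound 1 to compound 2, a step that the two limits leave unreadable from compound 1 to compound 3 and a step that the two limits leave unreadable from compound 2 to compound 3. Because (the limit of > 64 ug/mL in this assay, at which 3 of the 3 values shown sit), varying the group on the ester carbonyl carbon has so far not moved any reading off the limit. Compound 4 `C=CC(=O)OC1CCC(CN2CCN(c3cc(=O)c4cc(C(F)(F)F)cc([N+](=O)[O-])c4s3)CC2)CC1` differs from compound 1 by vinyl in place of 3-methylphenyl on a carbonyl carbon. Among the measured compounds shown here, no measured step involves a vinyl group, so nothing measured speaks for a change. The reviewer therefore expects compound 4 to stay at the limit, with a number no higher from compound 1 to compound 4 (the limit leaves the size open) meaning no change beyond the scatter, and estimates 64 ug/mL in this assay, between 16 ug/mL and 128 ug/mL.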

Compound 4, half-maximal inhibitory concentration: > 64 ug/mL
Compound 4: no number, only a limit; the forecaster's own chance of this, stated with the estimate: 70%; the middle value lies on the limit itself.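

No step from compound 1, compound 2 or compound 3 to compound 4 can be read in this assay, because all four readings are limits: the limit of > 64 ug/mL in this assay, at which 4 of the 4 values shown sit.

The compounds shown leave open whether any group on the ester carbonyl carbon moves the reading off that limit.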